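A Cyano Group Takes the Place of Methyl

This account rests on a few compounds, and the source may have more. Where it says the series, first, only, none or still open, it means among the compounds named here.

In an ADME assay on THP-1 cells (Homo sapiens) for cytotoxicity, read by trypan blue exclusion, with a stated time of 24 h (on this read-out higher numbers stand for weaker inhibition and lower numbers for stronger inhibition), compound 1 `N#C[Se]Cc1ccc(Br)cc1` gives 28900 nM, compound 2 `CSc1ccc(C[Se]C#N)cc1` gives 17000 nM and compound 3 `Cc1ccc(C[Se]C#N)cc1` gives 24000 nM. Compound 3 therefore lies within the scatter of both neighbours. Compound 4 `N#C[Se]Cc1ccc(C#N)cc1` differs from it in one place: cyano in place of methyl on an aromatic carbon. Three measured steps, all swaps of a group at that same place, bear on this change: a 1.7-fold lower number from compound 1 to compound 2 (0.23 log units; within the scatter), a 1.2-fold lower number from compound 1 to compound 3 (0.08 log units; within the scatter) and a 1.4-fold higher number from compound 2 to compound 3 (0.15 log units; within the scatter). All three stay within the scatter, though none of them involves cyano itself. No change beyond the scatter is therefore expected in this assay. The estimated step is a 1.2-fold lower number from compound 3 to compound 4 (0.08 log units; within the scatter). For compound 4 the expected value is 20000 nM, with an estimated range of 10000 nM to 36000 nM.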

Compound 4, half-maximal inhibitory concentration: 7970 nM
The estimate for compound 4 lay 2.5-fold (0.40 log units) above the measured number; measured number below the stated range.
By their numbers in this assay, from the lowest: compound 4; then compounds 2, 3 and 1 (each within the scatter of the next).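

At this place on the ring, swaps among bromo, methylsulfanyl and methyl stayed within the scatter, but cyano moves the number beyond it in this assay: there is a 3.0-fold lower number from compound 3 to compound 4 (0.48 log units; beyond the scatter) and a 2.1-fold lower number from compound 2 to compound 4 (0.33 log units; beyond the scatter) and a 3.6-fold lower number from compound 1 to compound 4 (0.56 log units; beyond the scatter). Compound 4 thus stands apart as the lowest of the four, so this position is not indifferent to what sits on it. Nothing available explains why cyano differs from the other three groups. As far as these compounds go, whether an amine, a carboxylic acid or a longer chain at this place would also shift the number remains open, as does whether the shift belongs to cyano alone.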